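Adding a third hydroxy to a hexylamide of caffeic acid

A few compounds are considered here, and "the series" means these few. Any claim that something is new, unique, unknown or untested is made for them only; others in the source may bear on it.

Measured compounds:
compound 1, `O=C(O)/C=C/c1cc(O)c(O)c(O)c1`, 19000 nM
compound 2, `CCCCCCNC(=O)/C=C/c1ccc(O)c(O)c1`, 6600 nM

Of the compounds shown here, two have been measured in a functional assay on cells (Neutrophil, Homo sapiens) for inhibition, read by chemiluminescence, with stated times of 5 min and 15 min; a higher number here means a weaker inhibitor, a lower number a stronger inhibitor. Compound 2 stands at the lowest of the two numbers; in this assay compound 1 gives 19000 nM, a higher number than compound 2, and this gap lies beyond the usual scatter. Compound 1 and compound 2 differ in two places at once, so their pair tells nothing about either change on its own.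

Compound 3, `CCCCCCNC(=O)/C=C/c1cc(O)c(O)c(O)c1`, is not yet measured. It differs from compound 2 in one place: hydroxy in place of hydrogen on an aromatic carbon. Within the data shown here, no measured pair isolates this change, so its size is unknown here. The expectation is that the step from compound 2 to compound 3 in this assay, a 1.1-fold lower number from compound 2 to compound 3 (0.04 log units; within the scatter), stays within the scatter, with no firm direction. Compound 3 is therefore estimated at 6000 nM, with a range from 2000 nM to 20000 nM.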

Compound 3, half-maximal inhibitory concentration: 36000 nM
Compound 3: the middle estimate sits 6.0-fold (0.78 log units) below what was measured; measured number outside the range, above it.
By their numbers in this assay, from the lowest: compound 2; then compounds 1 and 3 (each within the scatter of the next).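

In this assay, among these compounds, hydroxy in place of hydrogen on an aromatic carbon, ortho to a hydroxy group, is the first change here that can be read on its own: it gives a 5.5-fold higher number from compound 2 to compound 3 (0.74 log units; beyond the scatter), so on the hexylamide this position does not take the added hydroxy without a loss of inhibition. Among the compounds shown here, with three hydroxy groups on the ring, compound 1 at 19000 nM and compound 3 at 36000 nM lie within the scatter of each other, so the hexylamide and the carboxylic acid show no separation in this pair. Nothing given here accounts for the loss.

Going by these compounds, it remains open whether the same hydroxy has a step of this size on the carboxylic acid. On these data alone, it is also open whether a methoxy at this position, or a longer chain on the amide, would behave the same way.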